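A few compounds are considered here, and "the series" means these few. Any claim that something is new, unique, unknown or untested is made for them only; others in the source may bear on it.

Compound 1 `O=C(c1cc(Cc2n[nH]c(=O)c3ccccc23)ccc1F)N1CCc2nc(Cl)ncc2C1` carries a chlorine on its core, and in a functional assay on MDA-MB-231 cells (Homo sapiens) for inhibition, read by MTT assay, with a stated time of 48 h (a lower number here means a stronger inhibitor, a higher number a weaker inhibitor), compound 1 has no reported result, "nd" (no result reported). Compound 2 `CN1CCN(c2ncc3c(n2)CCN(C(=O)c2cc(Cc4n[nH]c(=O)c5ccccc45)ccc2F)C3)CC1` instead bears a 4-methylpiperazin-1-yl group. In this assay compound 2 gives only a limit, > 200000 nM. Compound 2 thus stands at the limit of > 200000 nM in this assay, at which 1 of the 2 values shown sits. Compound 3 `CCN1CCN(c2ncc3c(n2)CCN(C(=O)c2cc(Cc4n[nH]c(=O)c5ccccc45)ccc2F)C3)CC1` differs from compound 2 by methyl in place of hydrogen on a saturated chain carbon bound to an amine nitrogen in a ring, so the methyl becomes ethyl. Within the data shown here, no measured step between compounds exists here, and the step expected from compound 2 to compound 3 is a step that the limit leaves unreadable from compound 2 to compound 3, nothing beyond the scatter in either direction. Compound 3 is therefore estimated at 250000 nM, expected within 100000 nM to 1000000 nM, most likely again reported only as a limit.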

Compound 3, half-maximal inhibitory concentration: > 200000 nM
Compound 3 ended at the assay's limit; the forecaster's own chance of this, stated with the estimate: 85%; the middle value is on the limit's open side.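

Among these compounds, compound 2 and compound 3 both reach only a limit in this assay, not a number, so no step between them can be read. The compounds shown leave open how 4-methylpiperazin-1-yl and 4-ethylpiperazin-1-yl actually compare.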